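Swapping the aryl group on the triazole benzyl arm

The source may report more compounds than this note shows. Statements on the series, on what has been measured and on what is new or still open speak of the compounds shown alone.

Compound 1 `O=C1N[C@H]2[C@H](CS[C@H]2CCCCCc2cn(Cc3ccccc3O)nn2)N1`: in an assay on isolated protein for inhibition of biotin--protein ligase (Homo sapiens), read by scintillation counting, with a stated time of 10 min (on this read-out higher numbers stand for weaker inhibition and lower numbers for stronger inhibition), compound 1 gives > 16000 nM, a limit of the assay.
Compound 2 `COc1cccc(Cn2cc(CCCCC[C@@H]3SC[C@@H]4NC(=O)N[C@@H]43)nn2)c1`: in this assay compound 2 gives > 16000 nM, likewise a limit.

Both measured compounds sit at the same limit, so the change from compound 1 to compound 2, a 3-methoxyphenyl in place of a 2-hydroxyphenyl on a saturated chain carbon bound to an aromatic nitrogen, gives a step that the two limits leave unreadable from compound 1 to compound 2. Compound 2 therefore stands only at a limit; no number places it (the limit of > 16000 nM in this assay, at which 2 of the 2 values shown sit).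

Compound 3 `Nc1ccccc1Cn1cc(CCCCC[C@@H]2SC[C@@H]3NC(=O)N[C@@H]32)nn1` differs from compound 2 in one place: 2-aminophenyl in place of 3-methoxyphenyl on a saturated chain carbon bound to an aromatic nitrogen. Going by the values given here, no measured step bears on this change, since the one step recorded cannot be read. Without a readable step, the expectation for compound 3 rests only on both neighbours resting at the limit: a step that the limit leaves unreadable from compound 2 to compound 3 is estimated, that is, no change beyond the scatter, and compound 3 is expected to give 25000 nM in this assay, most likely again reported as a limit, within 6000 nM to 100000 nM.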

Compound 3, inhibition constant: > 16000 nM
Compound 3 ended at the assay's limit (the forecaster's own chance of this, stated with the estimate: 70%); the middle value does not contradict the limit.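

Compound 1, compound 2 and compound 3 all rest at a limit of the assay rather than at a number, so no step among them can be read: the limit of > 16000 nM in this assay, at which 3 of the 3 values shown sit.

The compounds shown leave open whether swapping among the 2-hydroxyphenyl, 3-methoxyphenyl and 2-aminophenyl groups changes inhibition at all in this assay, and how weak each compound truly is.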